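This account rests on a few compounds, and the source may have more. Where it says the series, first, only, none or still open, it means among the compounds named here.

Measured: compound 1 `CCCCCCCCS(=O)(=O)Nc1ccc(-c2ccc(Cl)cc2)cc1C(=O)O`, 9200 nM; compound 2 `CCCCCCCCS(=O)(=O)Nc1ccc(/C=C/c2ccc(OC)cc2)cc1C(=O)O`, 37100 nM.

Going by the values given here, in an assay on mitochondria (strain BALB/c) for inhibition of glycerol-3-phosphate acyltransferase 1, mitochondrial (Mus musculus), read by scintillation counting, with a stated time of 10 min (a higher number here means a weaker inhibitor, a lower number a stronger inhibitor), compound 2 gives the higher of the two numbers, and the only step measured, a 4.0-fold higher number from compound 1 to compound 2 (0.61 log units; beyond the scatter), lies beyond the scatter. Compound 3 `CCCCCCCCS(=O)(=O)Nc1ccc(CCc2ccccc2)cc1C(=O)O` differs from compound 2 by phenethyl in place of 2-(4-methoxyphenyl)ethenyl on an aromatic carbon. Among the compounds with values here, no measured step alters only the linker or only the methoxy group, so that one step bears on the change only loosely. The number for compound 3 is expected to sit between the two measured ones, the estimated step being a 1.9-fold lower number from compound 2 to compound 3 (0.27 log units; within the scatter). Compound 3 is estimated at 20000 nM, with a range of 6000 nM to 60000 nM.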

Compound 3, half-maximal inhibitory concentration: 37500 nM
Compound 3: middle estimate off by 1.9-fold (0.27 log units), on the low side, within the range that was stated.
By their numbers in this assay, from the lowest: compound 1; then compounds 2 and 3 (each within the scatter of the next).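

In this assay, phenethyl in place of 2-(4-methoxyphenyl)ethenyl gives a 1.0-fold higher number from compound 2 to compound 3 (0.00 log units; within the scatter) and so does not separate these two groups at this position, even though the double bond and the methoxy group leave together. Phenethyl in place of 4-chlorophenyl gives a 4.1-fold higher number from compound 1 to compound 3 (0.61 log units; beyond the scatter) and leaves compound 1 the strongest of the three. No measurement on hand accounts for either step.

Going by these compounds alone, whether the double bond and the methoxy group each matter alone stays open, since no step changes only one. Also open, on these data alone, is how an amine or a carboxylic acid in place of the chlorine of compound 1 would read.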